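Two Anilinopyrimidines Compared, a Third Awaiting Its Number

A few compounds are considered here, and "the series" means these few. Any claim that something is new, unique, unknown or untested is made for them only; others in the source may bear on it.

Measured compounds:
compound 1, `Cc1ccccc1Nc1nc(Nc2cccnc2)ncc1Cl`: 22900 nM
compound 2, `Cc1ccccc1Nc1nc(Nc2ccc(N3CCN(C)CC3)cn2)ncc1Cl`: 5980 nM

In an ADME assay on L02 cells (Homo sapiens) for inhibition, read by CCK-8 assay, with a stated time of 48 h (on this read-out lower numbers stand for stronger inhibition of growth and higher numbers for weaker inhibition of growth), compound 2 gives 5980 nM, and this is the lower of the two numbers measured. Compound 1 gives 22900 nM in this assay, a higher number, and the gap between the two lies beyond the scatter of repeated measurement. The two differ in more than one place, so the gap is not assigned to any single change; it is simply what the two values show.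

Compound 3, `COc1ccc(Nc2nc(Nc3ccc(N4CCN(C)CC4)cn3)ncc2Cl)cc1`, has not yet been measured in this assay. It differs from compound 2 in one place: 4-methoxyphenyl in place of 2-methylphenyl on a nitrogen on an aromatic ring. The rest of the shared core, and the group on the other nitrogen of that core, are unchanged.

Within the data shown here, because compound 2 gives 5980 nM and no measured pair isolates this particular change, the expectation for compound 3 is anchored on that value alone. The step expected from compound 2 to compound 3 in this assay is a 1.2-fold higher number from compound 2 to compound 3 (0.07 log units; within the scatter), which is not expected to exceed the scatter in either direction. Compound 3 is therefore estimated at 7000 nM, within a range of 2500 nM to 20000 nM.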

Compound 3, concentration for 50% growth inhibition: 3150 nM
The estimate for compound 3 lay 2.2-fold (0.35 log units) above the measured number, within the range that was stated.
By their numbers in this assay, from the lowest: compounds 3 and 2 (each within the scatter of the next); then compound 1.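

Among these compounds, compound 3 supplies the first step that isolates a single change at this position: with 4-methoxyphenyl in place of 2-methylphenyl on a nitrogen on an aromatic ring, this assay shows a 1.9-fold lower number from compound 2 to compound 3 (0.28 log units; within the scatter). The earlier pair could not show this, as compound 1 and compound 2 differ in more than one place, so their gap said nothing about this nitrogen on its own. Here the exchange brings in one more heavy atom, an oxygen counted as a hydrogen-bond acceptor, yet compound 2 and compound 3 cannot be told apart in this read-out, and nothing at hand offers an explanation for that.

Among the compounds shown here, this single pair cannot say whether the same exchange would give a similar step when the group on the other nitrogen of the shared core is the one carried by compound 1. It also leaves open what an amine, a carboxylic acid or a longer chain would do on the ring attached to this nitrogen, and whether any such group would move the number beyond the scatter in this assay.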